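The source may hold more compounds than are shown below. What is called first, only, known or untested is meant among the compounds shown, and "the series" means these compounds.

Compound 1 `Cc1cc(Br)c(S(C)(=O)=O)cc1C(=O)N=C(N)N` and compound 2 `Cc1cc(-c2ccc(F)cc2)c(S(C)(=O)=O)cc1C(=O)N=C(N)N` share one core and differ only at a single aromatic carbon. In a functional assay for inhibition of sodium/hydrogen exchanger (Oryctolagus cuniculus) (a higher number here means a weaker inhibitor, a lower number a stronger inhibitor), compound 1 gives 12 nM, while compound 2 gives 36 nM. For the measured compounds named here, the one step measured, a 3.0-fold higher number from compound 1 to compound 2 (0.48 log units; beyond the scatter), leaves compound 2 with the highest number of the two measured values, with compound 1 as its only neighbour. Compound 3 `Cc1cc(SC(C)(C)C)c(S(C)(=O)=O)cc1C(=O)N=C(N)N` carries the next change at the same aromatic carbon: (tert-butyl)sulfanyl in place of 4-fluorophenyl on an aromatic carbon. Going by the values given here, no measured step involves a (tert-butyl)sulfanyl group, so the only guidance is that this carbon tolerates both bromo and 4-fluorophenyl, with a step of modest size between them; a comparable step is therefore expected here, most likely toward a lower number, though it may well remain within the scatter. Compound 3 is thus expected to return 20 nM in this assay, in a range from 6 nM to 70 nM. This estimate corresponds to an expected step of a 1.8-fold lower number from compound 2 to compound 3 (0.26 log units; within the scatter).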

Compound 3, half-maximal inhibitory concentration: 22 nM
Compound 3: the middle estimate sits 1.1-fold (0.04 log units) below what was measured, within the range that was stated.
By their numbers in this assay, from the lowest: compounds 1, 3 and 2 (each within the scatter of the next, the first and the last beyond it).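

In this assay, the (tert-butyl)sulfanyl group of compound 3 cannot be told apart from either earlier group at this aromatic carbon, with a 1.6-fold lower number from compound 2 to compound 3 (0.21 log units; within the scatter) and a 1.8-fold higher number from compound 1 to compound 3 (0.26 log units; within the scatter). This carbon, ortho to a methylsulfonyl group, therefore also accommodates a group with no ring, and compound 3 lies within the scatter of both compound 1 and compound 2, although those two lie beyond the scatter of each other. No measurement available here explains why these three groups give such similar numbers.

The compounds shown leave open whether an amine, a carboxylic acid or a longer alkyl chain at this carbon would give numbers in the same range. They also leave open whether a smaller methylsulfanyl group would read like the (tert-butyl)sulfanyl group.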